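From Amino to Methoxy on the Shared Core

The source may report more compounds than this note shows. Statements on the series, on what has been measured and on what is new or still open speak of the compounds shown alone.

In a functional assay on HepG2 cells (Homo sapiens) for antiproliferative activity, read by MTT assay, with a stated time of 48 h (a lower number here means a stronger inhibitor, a higher number a weaker inhibitor), compound 1 (`CCCCCCCCCCCCOc1ccc(C(=O)/C=C/c2c(/C=C/c3ccc(OC)cc3)cc(OC)cc2OC)cc1`) gives 11.6 ug/mL and compound 2 (`COc1ccc(/C=C/c2cc(OC)cc(OC)c2/C=C/C(=O)c2ccc(N)cc2)cc1`) gives 7.5 ug/mL so these two numbers sit within the usual scatter of each other. The unmeasured compound 3 (`COc1ccc(/C=C/c2cc(OC)cc(OC)c2/C=C/C(=O)c2ccc(OC)cc2)cc1`) differs from compound 2 by carrying methoxy in place of amino on an aromatic carbon and by nothing else. Going by the values given here, no measured pair shows this swap, so the data offer no direct guide to its size. The expected step of a 1.2-fold higher number from compound 2 to compound 3 (0.08 log units; within the scatter) is small and stays within the scatter. For compound 3 the estimate is 9 ug/mL with an expected range from 4 ug/mL to 20 ug/mL as the likely span.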

Compound 3, half-maximal inhibitory concentration: 4.9 ug/mL
The estimate for compound 3 lay 1.8-fold (0.26 log units) above the measured number; the measured number falls inside the stated range.
By their numbers in this assay, from the lowest: compounds 3, 2 and 1 (each within the scatter of the next, the first and the last beyond it).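

Putting methoxy in place of amino at this place, para to a large group, gives a 1.5-fold lower number from compound 2 to compound 3 (0.18 log units; within the scatter) in this assay, so amino is not needed to keep this level of activity on the shared core. Going by these compounds alone, replacing the long chain on the same oxygen, hydrogen in place of undecyl, gives a 2.4-fold lower number from compound 1 to compound 3 (0.37 log units; beyond the scatter), the only step here beyond the scatter. Nothing available explains either step. From the compounds shown here alone, whether a hydroxyl, a dimethylamino group or a carboxylic acid at this place would fit the same picture stays open. So does how an ethoxy or butoxy group would compare with the methoxy of compound 3.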